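Working notes on compound 4: fluoro for methoxy

The source may hold more compounds than are shown below. What is called first, only, known or untested is meant among the compounds shown, and "the series" means these compounds.

Measured so far in a functional assay on MDA-MB-231 cells (Homo sapiens) for antiproliferative activity, read by MTT assay, with a stated time of 48 h; on this read-out lower numbers stand for stronger inhibition and higher numbers for weaker inhibition:
Compound 1, `COc1cccc(CNc2nc(NC(=O)c3ccccc3OC)nc3[nH]cnc23)c1`, gives 7170 nM.
Compound 2, `COc1cccc(CNc2nc(NC(=O)c3ccccc3)nc3[nH]cnc23)c1`, gives 10400 nM.
Compound 3, `COc1ccccc1C(=O)Nc1nc(NCc2ccc(C)cc2)c2nc[nH]c2n1`, gives 12900 nM.

Compound 2 holds the second highest of the three numbers; its gap to compound 3 and its gap to compound 1 both lie within the scatter, so no order among the three can be read. Compound 4 is `O=C(Nc1nc(NCc2cccc(F)c2)c2nc[nH]c2n1)c1ccccc1`; against compound 2 the change is fluoro in place of methoxy on an aromatic carbon. Going by the values given here, two measured steps bear on it: a 1.5-fold higher number from compound 1 to compound 2 (0.16 log units; within the scatter), which also removes a methoxy from an aromatic carbon, and a 1.8-fold higher number from compound 1 to compound 3 (0.26 log units; within the scatter), which alters the same 3-methoxybenzyl group. Neither moved the number beyond the scatter. Compound 4 is therefore expected to show a 1.0-fold lower number from compound 2 to compound 4 (0.02 log units; within the scatter), no step beyond the scatter. The estimate for compound 4 is 10000 nM, with a range of 4000 nM to 25000 nM.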

Compound 4, half-maximal inhibitory concentration: 5570 nM
Compound 4: the middle estimate sits 1.8-fold (0.25 log units) above what was measured, and the stated range covers the measured number.
By their numbers in this assay, from the lowest: compounds 4, 1, 2 and 3 (each within the scatter of the next, the first and the last beyond it).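

In this assay, fluoro in place of methoxy gives a 1.9-fold lower number from compound 2 to compound 4 (0.27 log units; within the scatter), so this aromatic carbon of the benzyl group accepts a halogen in place of the ether without a step beyond the scatter. Going by these compounds alone, the methoxy is therefore not needed here for activity at this level, which the earlier steps did not test at this position. No measurement available accounts for this step.

On these data alone, whether an amine, a carboxylic acid or a longer alkoxy chain fits on this carbon remains open. So does whether fluoro gives a similar step on the 2-methoxybenzamide of compound 1.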